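The source may hold more compounds than are shown below. What is called first, only, known or untested is meant among the compounds shown, and "the series" means these compounds.

Working notes on the series. Compound 2 `CN(C(=S)SCc1ccc(C(=O)Nc2ccccc2N)cc1)c1cccnc1` gives 16% in a functional assay on HeLa cells (Homo sapiens) for antiproliferative activity, read by CCK-8 assay, with a stated time of 72 h, tested at 2 uM (on this read-out higher numbers stand for a stronger effect at the one concentration tested and lower numbers for a weaker effect), the lowest of the three numbers measured. Compound 1 `Nc1ccccc1NC(=O)c1ccc(CSC(=S)N2CCN(c3cccnc3)CC2)cc1` gives 66.2% and compound 3 `Nc1ccccc1NC(=O)c1ccc(CSC(=S)N2CCN(Cc3ccncc3)CC2)cc1` gives 59.5%, both well above compound 2, beyond the scatter. Among the measured compounds shown here, the only measured step, a number 6.7 percentage points lower from compound 1 to compound 3 (within the scatter), shows that exchanging the substituent on the piperazine nitrogen changes little. Compound 4 `CN1CCN(C(=S)SCc2ccc(C(=O)Nc3ccccc3N)cc2)CC1` differs from compound 2 by 4-methylpiperazin-1-yl in place of methyl(pyridin-3-yl)amino on a thiocarbonyl carbon. For the measured compounds named here, no measured step covers this exact exchange; what bears on it is that both compounds carrying a piperazine ring on the thiocarbonyl carbon, compound 1 and compound 3, read far higher than compound 2. An upward step is therefore expected, though its size is uncertain, estimated as a number 29 percentage points higher from compound 2 to compound 4 (beyond the scatter). Compound 4 is expected at 45%, in the range 20% to 68%.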

Compound 4, a percentage reported as inhibition, at one concentration (the size of the read-out at that concentration, not a potency): 52.6%
Compound 4: the middle estimate sits 7.6 percentage points below what was measured, and the stated range covers the measured number.
By their numbers in this assay, from the lowest: compound 2; then compounds 4, 3 and 1 (each within the scatter of the next, the first and the last beyond it).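

In this assay, 4-methylpiperazin-1-yl on the thiocarbonyl carbon gives a number 36.6 percentage points higher from compound 2 to compound 4 (beyond the scatter), so a piperazine ring there holds the read-out without any pyridinyl group. On the ring amine nitrogen, methyl in place of pyridin-3-yl gives a number 13.6 percentage points lower from compound 1 to compound 4 (beyond the scatter), a modest loss, while removing pyridin-4-yl from the saturated chain carbon gives a number 6.9 percentage points lower from compound 3 to compound 4 (within the scatter), so that group adds nothing that can be read. Nothing available explains these steps.

On these data alone, it remains open whether the low number of compound 2 follows from its unringed amine or from its pyridin-3-yl. A dimethylamino or morpholin-4-yl group on the thiocarbonyl carbon would separate the two.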